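Swapping Out the 2-Cyanocyclopropyl Group

The source may report more compounds than this note shows. Statements on the series, on what has been measured and on what is new or still open speak of the compounds shown alone.

In an ADME assay on MDCKII-LE cells (Canis lupus familiaris) for permeability (on this read-out lower numbers stand for lower permeability and higher numbers for higher permeability), compound 1 `N#CC12CC(CN([C@H](CCC(F)(F)F)C(N)=O)S(=O)(=O)c3ccc(Cl)cc3)(C1)C2` gives 30.2 10^-6 cm/s, compound 3 `N#C[C@H]1C[C@@H](CN([C@H](CCC(F)(F)F)C(N)=O)S(=O)(=O)c2ccc(Cl)cc2)C1` gives 24.1 10^-6 cm/s, and compound 2 `N#C[C@@H]1C[C@H]1CN([C@H](CCC(F)(F)F)C(N)=O)S(=O)(=O)c1ccc(Cl)cc1` gives 9.94 10^-6 cm/s, the lowest of the three. Compound 4 `NC(=O)[C@@H](CCC(F)(F)F)N(C[C@H]1C[C@@H](c2ncon2)C1)S(=O)(=O)c1ccc(Cl)cc1` differs from compound 2 in one place: 3-(1,2,4-oxadiazol-3-yl)cyclobutyl in place of 2-cyanocyclopropyl on a saturated chain carbon bound to a sulfonamide nitrogen. The closest guide is a 2.4-fold higher number from compound 2 to compound 3 (0.38 log units; beyond the scatter), where 3-cyanocyclobutyl replaces 2-cyanocyclopropyl. A similar gap appears in a 3.0-fold lower number from compound 1 to compound 2 (0.48 log units; beyond the scatter), whereas a 1.3-fold lower number from compound 1 to compound 3 (0.10 log units; within the scatter) shows that the two groups with four-membered rings stay close. For the measured compounds named here, no measured compound carries 3-(1,2,4-oxadiazol-3-yl)cyclobutyl, so this guide is imperfect. A modest rise is therefore expected in this assay, with an estimated 2.1-fold higher number from compound 2 to compound 4 (0.32 log units; beyond the scatter). For compound 4 the estimated value is 21 10^-6 cm/s, with an expected range from 9 10^-6 cm/s to 40 10^-6 cm/s.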

Compound 4, apparent permeability: 14.1 10^-6 cm/s
Beside the measured number, compound 4's estimate is 1.5-fold (0.17 log units) above it; the measured number falls inside the stated range.
By their numbers in this assay, from the lowest: compounds 2, 4, 3 and 1 (each within the scatter of the next, the first and the last beyond it).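

In this assay, putting 3-(1,2,4-oxadiazol-3-yl)cyclobutyl in place of 2-cyanocyclopropyl gives no change beyond the scatter, with a 1.4-fold higher number from compound 2 to compound 4 (0.15 log units; within the scatter). Exchanging cyano for 1,2,4-oxadiazol-3-yl on the cyclobutyl ring also stays within the scatter, at a 1.7-fold lower number from compound 3 to compound 4 (0.23 log units; within the scatter), so the larger group with its added aromatic ring gives no clear shift in either of these two steps. For the compounds shown here, only the step from the group with two four-membered rings passes the scatter, at a 2.1-fold lower number from compound 1 to compound 4 (0.33 log units; beyond the scatter).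

No measurement shown here explains these numbers. From the compounds shown here alone, whether an amine or a carboxylic acid in place of the oxadiazole on the cyclobutyl ring would keep the number in this range stays open.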